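Benzoxazole sulfonamides against mitochondrial malate dehydrogenase

The source may hold more compounds than are shown below. What is called first, only, known or untested is meant among the compounds shown, and "the series" means these compounds.

Compound 1 `COc1cccc(S(=O)(=O)Nc2ccc3oc(-c4ccccc4)nc3c2)c1`: in an assay on isolated protein for inhibition of malate dehydrogenase, mitochondrial (Sus scrofa), with stated times of 45 min and 30 min (a lower number here means a stronger inhibitor, a higher number a weaker inhibitor), compound 1 gives > 63000 nM, a limit of the assay.
Compound 2 `COc1ccc(S(=O)(=O)Nc2ccc3oc(-c4ccccc4)nc3c2)cc1`: compound 2 gives > 63000 nM, also a limit.
Compound 3 `COc1ccc(S(=O)(=O)Nc2ccc(-c3nc4ccccc4o3)cc2)cc1`: compound 3 gives > 63000 nM, again a limit.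

The difference between the core of compound 2 and the core of compound 3 is not broken down here. Compound 1 and compound 2 differ by 3-methoxyphenyl in place of 4-methoxyphenyl on a sulfonyl sulfur and the step that the two limits leave unreadable from compound 2 to compound 1. Compound 4 `COc1cccc(S(=O)(=O)Nc2ccc(-c3nc4ccccc4o3)cc2)c1` is not yet measured; it differs from compound 3 by 3-methoxyphenyl in place of 4-methoxyphenyl on a sulfonyl sulfur, the same change, at the same place. Among the compounds with values here, the only evidence is the limit of > 63000 nM in this assay, at which 3 of the 3 values shown sit. Since the step from compound 2 to compound 1 was unreadable because of the limit of > 63000 nM in this assay, at which 3 of the 3 values shown sit, the expected step is a step that the limit leaves unreadable from compound 3 to compound 4, with compound 4 expected again at the limit. Compound 4 is estimated at 100000 nM, between 30000 nM and 400000 nM.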

Compound 4, half-maximal inhibitory concentration: > 63000 nM
Compound 4 was reported as a limit (the forecaster's own chance of this, stated with the estimate: 90%); the middle value lies beyond the limit too.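

No step can be read between compound 3 and compound 4, as both stand at a limit: the limit of > 63000 nM in this assay, at which 4 of the 4 values shown sit.

The compounds shown leave open which change to the shared structure, if any, would give a readable value in this assay.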